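This account rests on a few compounds, and the source may have more. Where it says the series, first, only, none or still open, it means among the compounds named here.

Measured so far in a functional assay on NCI-H23 cells (Homo sapiens) for inhibition, read by sulforhodamine B assay, with a stated time of 48 h; on this read-out lower numbers stand for stronger inhibition of growth and higher numbers for weaker inhibition of growth:
- compound 1 `Nc1cc(N)c2nc(-c3ccccc3)c(NCc3ccc(Cl)c(Cl)c3)nc2c1`: compound 1 gives 27500 nM
- compound 2 `COc1ccc(CNc2nc3cc(N)cc(N)c3nc2-c2ccccc2)cc1OC`: compound 2 gives 39800 nM
- compound 3 `Nc1cc(N)c2nc(-c3ccccc3)c(NCc3ccc(F)cc3)nc2c1`: compound 3 gives 4570 nM

Compound 3 stands lowest of the three, and both of its steps are beyond the scatter: a 6.0-fold lower number from compound 1 to compound 3 (0.78 log units; beyond the scatter) and an 8.7-fold lower number from compound 2 to compound 3 (0.94 log units; beyond the scatter). The two larger benzyl substituents sit close to each other, a 1.4-fold higher number from compound 1 to compound 2 (0.16 log units; within the scatter), so neither is separated from the other.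

Compound 4 `COc1ccc(CNc2nc3cc(N)cc(N)c3nc2-c2ccccc2)cc1` differs from compound 3 by methoxy in place of fluoro on an aromatic carbon. For the measured compounds named here, no measured step shows this single exchange on its own. The nearest is the pair compound 2 and compound 3, where a 3,4-dimethoxybenzyl is replaced by the 4-fluorobenzyl; it contains the same methoxy-for-fluoro exchange together with a second methoxy, and it runs an 8.7-fold lower number from compound 2 to compound 3 (0.94 log units; beyond the scatter). The dichloro compound 1 also lies well above compound 3, a 6.0-fold lower number from compound 1 to compound 3 (0.78 log units; beyond the scatter). Both steps point the same way: anything heavier than the single fluoro on the benzyl ring has so far gone with a higher number. Because the step of an 8.7-fold lower number from compound 2 to compound 3 (0.94 log units; beyond the scatter) contains a second methoxy as well as the methoxy-for-fluoro exchange, compound 4 is expected to rise by less than that full gap.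

Compound 4 is therefore estimated at 12000 nM, with a range from 4000 nM to 40000 nM. That expectation corresponds to a step of a 2.6-fold higher number from compound 3 to compound 4 (0.42 log units; beyond the scatter).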

Compound 4, concentration for total growth inhibition: 34700 nM
The estimate for compound 4 lay 2.9-fold (0.46 log units) below the measured number; low and high end bracket the measured number.
By their numbers in this assay, from the lowest: compound 3; then compounds 1, 4 and 2 (each within the scatter of the next).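

In this assay the exchange of methoxy for fluoro, on an aromatic carbon para to a large group, now stands alone (a 7.6-fold higher number from compound 3 to compound 4 (0.88 log units; beyond the scatter)), and this single change is enough to lift the number to the level of the other compounds in the series. The second methoxy of the 3,4-dimethoxyphenyl group adds nothing that can be separated (a 1.1-fold lower number from compound 2 to compound 4 (0.06 log units; within the scatter)), and 4-methoxyphenyl is likewise not separated from 3,4-dichlorophenyl (a 1.3-fold higher number from compound 1 to compound 4 (0.10 log units; within the scatter)), so compound 1, compound 2 and compound 4 form one level, with only compound 3 clearly apart from it. Nothing shown here gives a measured reason for the distinct result of the 4-fluorobenzyl compound.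

Open, going by these compounds, is whether the low number belongs to fluoro in particular or to any small group on that carbon, a question that a plain hydrogen, a chloro or a hydroxy there would help to settle. Also open, on these data alone, is how far the 4-fluorobenzyl result carries, as it rests on compound 3 alone, and whether it survives a longer chain in place of the single benzyl carbon.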